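A few compounds are considered here, and "the series" means these few. Any claim that something is new, unique, unknown or untested is made for them only; others in the source may bear on it.

Measured compounds:
compound 1 `COc1cc(/C=C/C(O)=C/C(=O)c2c(O)cccc2OC)ccc1O` gives 3760 nM
compound 2 `O=C(/C=C(O)/C=C/c1ccc(O)cc1)c1ccccc1O` gives 1520 nM

Both numbers come from an in vitro assay on cells for inhibition of Amine oxidase [flavin-containing] A (Homo sapiens), read by Amplex Red, with a stated time of 15 min (on this read-out lower numbers stand for stronger inhibition and higher numbers for weaker inhibition), so a smaller number means a stronger inhibitor. Of the two compounds measured, compound 1 stands at the higher number, 3760 nM. Compound 2 gives the lower number, 1520 nM, and the gap between the two lies beyond the usual scatter of repeated measurements, so compound 2 is the stronger inhibitor of this pair. No single-point change links these two compounds, so their values only show where each stands.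

Compound 3 `COc1cc(/C=C/C=C/C(=O)c2c(O)cccc2OC)ccc1O` has not yet been measured. It differs from compound 1 in one place: hydrogen in place of hydroxy on a double-bonded chain carbon bound to two double-bonded chain carbons. Going by the values given here, no measured pair shows this kind of change, so nothing is known about how large such a step tends to be. The expectation is therefore a cautious one: a step from compound 1 of about a 1.3-fold lower number from compound 1 to compound 3 (0.10 log units; within the scatter) in this assay, which is within the scatter rather than a clear shift in either direction. On this basis compound 3 is estimated at 3000 nM in this assay, with a plausible range from 1000 nM to 9000 nM.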

Compound 3, half-maximal inhibitory concentration: 1030 nM
The estimate for compound 3 lay 2.9-fold (0.46 log units) above the measured number; measured number inside the range.
By their numbers in this assay, from the lowest: compounds 3 and 2 (each within the scatter of the next); then compound 1.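

In this assay, putting hydrogen in place of hydroxy on a double-bonded chain carbon bound to two double-bonded chain carbons gives a 3.7-fold lower number from compound 1 to compound 3 (0.56 log units; beyond the scatter), a step beyond the usual scatter. The two earlier compounds could only show where each stood, whereas this pair gives the first size for a single change, and it shows that, with the rest of compound 1 left as it is, this hydroxy is not needed for inhibition: the compound without it is the stronger inhibitor. Nothing available here explains why the number falls, so the step records an effect and not its cause.

One pair cannot show whether the same change would give a step of similar size on another compound, such as compound 2, which also carries this hydroxy. On these data alone, it also remains open how a group other than hydroxy or hydrogen at this place, such as an amine or a fluorine atom, would compare with compound 3.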